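The source may report more compounds than this note shows. Statements on the series, on what has been measured and on what is new or still open speak of the compounds shown alone.

Two compounds of the series carry a number in an assay on Saliva for inhibition of Alpha amylase (Homo sapiens), with a stated time of 15 min; on this read-out lower numbers stand for stronger inhibition and higher numbers for weaker inhibition. Compound 1 `Cc1ccc2occ(/C=N/NC(=O)c3nc(-c4ccc(F)cc4)cs3)c(=O)c2c1` gives 19000 nM in this assay. Compound 2 `O=C(N/N=C/c1coc2cc(Br)ccc2c1=O)c1nc(-c2ccc(Cl)cc2)cs1` gives 6100 nM in this assay, the lower of the two numbers, and its gap to compound 1 lies beyond the usual scatter. Compound 3 `O=C(N/N=C/c1coc2cc(Br)ccc2c1=O)c1nc(-c2cccc(Br)c2)cs1` is not yet measured; it differs from compound 2 by 3-bromophenyl in place of 4-chlorophenyl on an aromatic carbon. Going by the values given here, with no comparable pair measured, the step is expected to stay within the scatter, in either direction. Compound 3 is therefore estimated at 7000 nM in this assay, between 2500 nM and 20000 nM, meaning an expected step of a 1.1-fold higher number from compound 2 to compound 3 (0.06 log units; within the scatter).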

Compound 3, half-maximal inhibitory concentration: 4460 nM
For compound 3 the middle estimate is 1.6-fold (0.20 log units) above the measured one, and the stated range covers the measured number.
By their numbers in this assay, from the lowest: compounds 3 and 2 (each within the scatter of the next); then compound 1.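

In this assay, 3-bromophenyl in place of 4-chlorophenyl on the aromatic carbon gives a 1.4-fold lower number from compound 2 to compound 3 (0.14 log units; within the scatter), the only step shown that changes a single place in the series. At this position, the read-out therefore stays within the scatter when this swap is made, although the halogen and its place on the phenyl ring change together and cannot be separated here. No available evidence bears on this result. Still open, on these data alone, is whether an unsubstituted phenyl, or an amine or a carboxylic acid on the phenyl ring, would give a step beyond the scatter.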